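A few compounds are considered here, and "the series" means these few. Any claim that something is new, unique, unknown or untested is made for them only; others in the source may bear on it.

Measured compounds in a functional assay on U-251 cells (Homo sapiens) for inhibition, read by sulforhodamine B assay, with a stated time of 48 h; on this read-out higher numbers stand for weaker inhibition of growth and lower numbers for stronger inhibition of growth:
- compound 1, `O=C1C=COC(/C=C/c2ccc(C(F)(F)F)cc2)C1`: 38.6 uM
- compound 2, `COc1ccc(/C=C/C2CC(=O)C=CO2)cc1`: 152 uM
- compound 3, `O=C1C=CCC(/C=C/c2ccc(C(F)(F)F)cc2)O1`: 36.8 uM

Compound 1 and compound 3 are built from the same atoms joined differently; the difference between the two cores is not broken down here. In this assay the two give numbers that sit within the scatter of each other, so no order between compound 1 and compound 3 is claimed.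

Compound 2 carries the same aryl-bearing side chain as compound 1 on the core of compound 1, with methoxy in place of trifluoromethyl on an aromatic carbon. That change gave a 3.9-fold higher number from compound 1 to compound 2 (0.60 log units; beyond the scatter). For the measured compounds named here, it is the only step of its kind measured so far, so nothing is known about how it behaves on another core.

Compound 4, `COc1ccc(/C=C/C2CC=CC(=O)O2)cc1`, is not yet measured. It stands to compound 3 as compound 2 stands to compound 1: methoxy in place of trifluoromethyl on an aromatic carbon. The place line reads the same in both cases, so this is the same change, now made on the core of compound 3.

Expectation for compound 4 in this assay: the step from compound 3 is estimated at a 3.8-fold higher number from compound 3 to compound 4 (0.58 log units; beyond the scatter), resting on the one measured instance of this change, where compound 1 to compound 2 showed a 3.9-fold higher number from compound 1 to compound 2 (0.60 log units; beyond the scatter), and on compound 3 starting from 36.8 uM. Because compound 3 gives 36.8 uM, close to compound 1, the estimated value for compound 4 is 140 uM, with a range from 60 uM to 330 uM to allow for a single precedent.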

Compound 4, concentration for growth inhibition (reported as GI): 20.6 uM
Compound 4: the middle estimate sits 6.8-fold (0.83 log units) above what was measured; the measured number lies below the stated range.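

In this assay, methoxy in place of trifluoromethyl on an aromatic carbon gives a 1.8-fold lower number from compound 3 to compound 4 (0.25 log units; within the scatter), so on the core of compound 3 this change does not separate the two compounds. The change therefore does not carry over from one core to the other with the same outcome, since the step seen on the core of compound 1 is not repeated on the core of compound 3, and the two steps differ: the same change on two cores in this assay, a 3.9-fold higher number (0.60 log units; beyond the scatter) from compound 1 to compound 2 and a 1.8-fold lower number (0.25 log units; within the scatter) from compound 3 to compound 4, 7.0-fold (0.85 log units) apart, beyond the scatter of two such steps. This shows that the outcome of the change depends on the core in this pair of cases, but it rests on one step per core and does not show what in the cores is responsible, nor how the change would behave on any further core.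

On these data alone, it remains open how other groups at the same aromatic carbon, such as a nitrile, an amine or a carboxylic acid, would read on each of the two cores, and whether they too would give steps that differ between the cores. Also open, as far as these compounds go, is whether a longer chain in place of the one joining the aromatic ring to the core would leave the dependence on the core as it stands in this assay.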